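The compounds below may be only part of what the source reports. "The series", "measured", "known", "first", "only" and "open" are said of these compounds alone.

Measured compounds:
compound 1 `CC(C)C[C@H](N)c1cc(C(F)(F)F)ccc1N1CCN(C(=O)CCc2ccccc2O)CC1`; in an assay on HEK293 cells for displacement of a labelled ligand from Melanocortin receptor 4 (Homo sapiens) (a lower number here means a stronger inhibitor, a higher number a weaker inhibitor), compound 1 gives 3300 nM.
compound 2 `Cc1cccc(CCC(=O)N2CCN(c3ccc(C(F)(F)F)cc3[C@@H](N)CC(C)C)CC2)c1`; in this assay compound 2 gives 2100 nM.
compound 3 `CC(C)C[C@H](N)c1cc(C(F)(F)F)ccc1N1CCN(C(=O)CCc2ccc(O)cc2)CC1`; in this assay compound 3 gives > 10000 nM, which is a limit of the assay rather than a number (the limit of > 10000 nM in this assay, at which 1 of the 3 values shown sits).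

Compound 3 thus stands at the weak end of the three: the steps of an at least 3.0-fold higher number from compound 1 to compound 3 (0.48 log units; beyond the scatter) and an at least 4.7-fold higher number from compound 2 to compound 3 (0.67 log units; beyond the scatter) both run to higher numbers. Compound 4 `COc1ccc(CCC(=O)N2CCN(c3ccc(C(F)(F)F)cc3[C@@H](N)CC(C)C)CC2)cc1` differs from compound 3 by methyl in place of hydrogen on an oxygen on an aromatic ring, so the 4-hydroxyphenyl becomes a 4-methoxyphenyl. Within the data shown here, no measured step exchanges a hydroxy for a methoxy, and the two steps that reach compound 3 only show that the 4-hydroxyphenyl carries the highest number here, giving no direction for the added methyl. The step of an at least 1.2-fold lower number from compound 3 to compound 4 (0.09 log units; that floor lies within the scatter) is therefore expected to stay within the scatter. Compound 4 in this assay is estimated at 8000 nM, with a range of 3000 nM to 25000 nM.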

Compound 4, inhibition constant: 350 nM
The estimate for compound 4 lay 23-fold (1.36 log units) above the measured number, and the stated range ends above it.
By their numbers in this assay, from the lowest: compound 4; then compounds 2 and 1 (each within the scatter of the next). At a limit, above all of these: compound 3.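

A single methyl on the oxygen turns the 4-hydroxyphenyl, the group with the highest number, into the 4-methoxyphenyl, the group with the lowest, in this assay: an at least 28-fold lower number from compound 3 to compound 4 (1.45 log units; beyond the scatter). Compound 3 gives a limit of the assay, not a number, so that size is only a floor: the limit of > 10000 nM in this assay, at which 1 of the 4 values shown sits. The 4-methoxyphenyl also outdoes both other rings, with a 6.0-fold lower number from compound 2 to compound 4 (0.78 log units; beyond the scatter) and a 9.4-fold lower number from compound 1 to compound 4 (0.97 log units; beyond the scatter).

On these data alone, what a 4-ethoxyphenyl or a 4-aminophenyl would give here stays open. So does whether a 3-methoxyphenyl would keep the gain.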